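The compounds below may be only part of what the source reports. "The series", "measured", "known", "first", "only" and "open" are said of these compounds alone.

In a functional assay on a cell-free system (Platelet, plasma, Homo sapiens) for inhibition (on this read-out higher numbers stand for weaker inhibition and lower numbers for stronger inhibition), compound 3 `O=C(O)COC1CCN(CCN(C(=O)c2ccc(F)cc2)c2ccc(Cl)cc2)CC1` gives 2000 nM, the second highest of three numbers. Compound 1 `Cc1ccc(N(CCN2CCC(OCC(=O)O)CC2)C(=O)c2ccc(F)cc2)cc1` gives 970 nM, and compound 2 `Cc1ccc(N(CCN2CCC(OCC(=O)O)CC2)C(=O)c2cccc(C(F)(F)F)c2)cc1` gives 20000 nM. Compound 4 `COc1cccc(C(=O)N(CCN2CCC(OCC(=O)O)CC2)c2ccc(Cl)cc2)c1` differs from compound 3 in one group: 3-methoxyphenyl in place of 4-fluorophenyl on a carbonyl carbon. The other measured step, a 2.1-fold higher number from compound 1 to compound 3 (0.31 log units; beyond the scatter), is modest and swaps methyl for chloro, away from the changing group, so it offers little guidance. The large step of a 21-fold higher number from compound 1 to compound 2 (1.31 log units; beyond the scatter) also removes 4-fluorophenyl from a carbonyl carbon, but 3-(trifluoromethyl)phenyl enters there. Taking that single step as a guide, with a different group entering, a smaller rise in this assay is expected: a 3.0-fold higher number from compound 3 to compound 4 (0.48 log units; beyond the scatter). Compound 4 is estimated at 6000 nM, with an expected range from 1500 nM to 20000 nM.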

Compound 4, half-maximal inhibitory concentration: 74 nM
Compound 4: the middle estimate sits 81-fold (1.91 log units) above what was measured; measured number outside the range, below it.
By their numbers in this assay, from the lowest: compound 4; then compound 1; then compound 3; then compound 2.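

In this assay, the group on the carbonyl carbon can push the number down as well as up: 3-methoxyphenyl in place of 4-fluorophenyl gives a 27-fold lower number from compound 3 to compound 4 (1.43 log units; beyond the scatter), whereas 3-(trifluoromethyl)phenyl in that place gave a 21-fold higher number from compound 1 to compound 2 (1.31 log units; beyond the scatter). These two steps run in opposite directions, although one starts from a compound carrying chloro and the other from one carrying methyl. Nothing available explains the drop. Still open, going by these compounds, is whether an ethoxy or hydroxy group could replace the methoxy group and keep the low number. Also open, on these data alone, is whether 3-methoxyphenyl gives a similar drop with methyl in place of chloro.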